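Tail amine variation on the biphenyl benzamide series

The source may report more compounds than this note shows. Statements on the series, on what has been measured and on what is new or still open speak of the compounds shown alone.

Working notes on three measured compounds and one open position. Compound 1 `CN(C)C1CCN(C(=O)CCCOc2cc(C(=O)N3CCCCc4sccc43)ccc2NC(=O)c2ccccc2-c2ccccc2)CC1` gives 20 nM in an assay on CHO cells for inhibition of Vasopressin V2 receptor (Homo sapiens), read by radioligand binding; a lower number here means a stronger inhibitor, a higher number a weaker inhibitor. Compound 2 `COc1cc(C(=O)N2CCCC(N(C)C)c3sccc32)ccc1NC(=O)c1ccccc1-c1ccccc1` gives 20 nM in this assay, so compound 1 stands level with compound 2 at the digits recorded, the two together at the lowest numbers of the set, all within the scatter of each other. Among the compounds with values here, compound 3 `O=C(Nc1ccc(C(=O)N2CCCCc3sccc32)cc1OCCCC(=O)N1CCC(N2CCCCC2)CC1)c1ccccc1-c1ccccc1` gives 30 nM in this assay; the only single-site step measured so far is a 1.5-fold higher number from compound 1 to compound 3 (0.18 log units; within the scatter), which stays within the scatter.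

Compound 4 `CN1CCCN(C(=O)CCCOc2cc(C(=O)N3CCCCc4sccc43)ccc2NC(=O)c2ccccc2-c2ccccc2)CC1` differs from compound 1 by 4-methyl-1,4-diazepan-1-yl in place of 4-(dimethylamino)piperidin-1-yl on a carbonyl carbon. The measured step from compound 1 to compound 3 also alters only this tail amine and moves the number by nothing beyond the scatter, so a change beyond the scatter is not expected here either. The expected step is therefore a 1.5-fold higher number from compound 1 to compound 4 (0.18 log units; within the scatter). For compound 4 the estimate in this assay is 30 nM, with a range from 10 nM to 90 nM.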

Compound 4, half-maximal inhibitory concentration: 10 nM
Compound 4: middle estimate off by 3.0-fold (0.48 log units), on the high side, and the stated range covers the measured number.
By their numbers in this assay, from the lowest: compounds 4, 1, 2 and 3 (each within the scatter of the next, the first and the last beyond it).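

In this assay, the tail amine on the carbonyl carbon accepts a seven-membered ring with 2 hetero atoms: a 2.0-fold lower number from compound 1 to compound 4 (0.30 log units; within the scatter) stays within the scatter, so 4-methyl-1,4-diazepan-1-yl and 4-(dimethylamino)piperidin-1-yl cannot be told apart here. Against the 4-(piperidin-1-yl)piperidin-1-yl tail, however, a 3.0-fold lower number from compound 3 to compound 4 (0.48 log units; beyond the scatter) gives the first modest separation at this position, showing that the choice of tail amine can register in this assay even though compound 1 and compound 3 stay within the scatter of each other. No supporting evidence bears on why the tail amines compare in this way.

Ring size and the placement of the second nitrogen change together in these compounds, so their contributions remain unseparated. 4-Methylpiperazin-1-yl, a six-membered counterpart, and morpholin-4-yl, with oxygen in place of the second nitrogen, would bear on that open question.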